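Working notes: substituent change at the core aromatic carbon

The source may hold more compounds than are shown below. What is called first, only, known or untested is meant among the compounds shown, and "the series" means these compounds.

Measured so far:
compound 1, `O=C(Nc1ccc(-c2cnc3cc(N4CCN(C5CC5)CC4)ccn23)cc1)c1ccc([N+](=O)[O-])o1`: in a functional assay on MGC-803 cells (Homo sapiens) for antiproliferative activity, read by CCK-8 assay, with a stated time of 72 h (on this read-out lower numbers stand for stronger inhibition and higher numbers for weaker inhibition), compound 1 gives 1650 nM
compound 2, `O=C(Nc1ccc(-c2cnc3cc(C4=CCN(C5COC5)CC4)ccn23)cc1)c1ccc([N+](=O)[O-])o1`: compound 2 gives 1100 nM

Compound 2 holds the lowest of the two numbers, with compound 1 nearest; the step of a 1.5-fold lower number from compound 1 to compound 2 (0.18 log units; within the scatter) stays within the scatter. Compound 3, `CC1(O)CCN(c2ccn3c(-c4ccc(NC(=O)c5ccc([N+](=O)[O-])o5)cc4)cnc3c2)CC1`, differs from compound 2 by a group of 8 heavy atoms (6 carbon, 1 nitrogen, 1 oxygen; one six-membered non-aromatic ring with 1 hetero atom) in place of a group of 10 heavy atoms (8 carbon, 1 nitrogen, 1 oxygen; one four-membered non-aromatic ring with 1 hetero atom, one six-membered non-aromatic ring with 1 hetero atom), on an aromatic carbon. Going by the values given here, the single measured step bears on it only loosely, as it changed the same aromatic carbon and moved the number within the scatter; no step beyond the scatter is therefore expected in this assay. For compound 3 the expected value is 1300 nM, range 500 nM to 3500 nM. The expected step is a 1.2-fold higher number from compound 2 to compound 3 (0.07 log units; within the scatter).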

Compound 3, half-maximal inhibitory concentration: 3100 nM
For compound 3 the middle estimate is 2.4-fold (0.38 log units) below the measured one; low and high end bracket the measured number.
By their numbers in this assay, from the lowest: compounds 2, 1 and 3 (each within the scatter of the next, the first and the last beyond it).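

Going by these compounds alone, at this aromatic carbon, the change from the group of compound 2 to 4-hydroxy-4-methylpiperidin-1-yl gives the first step beyond the scatter in this assay (a 2.8-fold higher number from compound 2 to compound 3 (0.45 log units; beyond the scatter)), so the substituent here can shift the number. The same entering group in place of 4-cyclopropylpiperazin-1-yl stays within the scatter (a 1.9-fold higher number from compound 1 to compound 3 (0.27 log units; within the scatter)). No supporting data bear on the reason for either step.

The compounds shown do not separate the contribution of the hydroxyl from that of the methyl on the piperidine. From the compounds shown here alone, how a morpholin-4-yl or 4-aminopiperidin-1-yl group would read at this position remains open.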